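The source may report more compounds than this note shows. Statements on the series, on what has been measured and on what is new or still open speak of the compounds shown alone.

Compound 1 `Nc1nc(OCC(F)(F)F)c2ncn(/C=C3/CC3(CO)CO)c2n1`, compound 2 `CN(C)c1nc(N)nc2c1ncn2/C=C1/CC1(CO)CO` and compound 3 `Nc1nc(NCc2ccccc2)c2ncn(/C=C3/CC3(CO)CO)c2n1` share one core. In an ADME assay on MOLT-3 cells (Homo sapiens) for cytotoxicity, with a stated time of 7 days (a lower number here means that less compound is tolerated, a higher number that more compound is tolerated), compound 1 sits at a limit of the assay, > 20000 nM, not at a number. For compound 2 this assay reports "not determined" (no result reported), so compound 2 has no number to stand on. The only measured point in the set is the limit of > 20000 nM in this assay, at which 1 of the 2 values shown sits. Compound 3 differs from compound 2 by benzylamino in place of dimethylamino on an aromatic carbon. Going by the values given here, with no measured step in this assay, no change beyond the scatter is expected in either direction. For compound 3 the estimate in this assay is 20000 nM, range 8000 nM to 50000 nM, with a limit rather than a number the likelier report.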

Compound 3, half-maximal cytotoxic concentration: > 20000 nM
Compound 3 gave a limit, no number; the forecaster's own chance of this, stated with the estimate: 70%; the middle value lies on the limit itself.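

Compound 1 and compound 3 both give limits rather than numbers in this assay, so no step between them can be read: the limit of > 20000 nM in this assay, at which 2 of the 3 values shown sit.

The compounds shown leave open whether any group at this place gives a number rather than a limit in this assay.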